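Compound 3 to compound 4: pyridin-2-yl for pyridazin-3-yl

A few compounds are considered here, and "the series" means these few. Any claim that something is new, unique, unknown or untested is made for them only; others in the source may bear on it.

In an ADME assay on cells (Hepatocyte, Rattus norvegicus) for metabolic stability (a lower number here means that the compound disappears faster, a higher number that the compound lasts longer), compound 3 `O=C(C1CCN(c2cccnn2)CC1)N1N=CC[C@H]1c1ccccc1` stands at < 0.517 h as a limit, not a number. Compound 2 `CC(=O)N1CCC(C(=O)N2N=CC[C@H]2c2ccccc2)CC1` stands at > 3.11 h as a limit too. Compound 1 `O=C(C1CCN(c2ncccn2)CC1)N1N=CC[C@H]1c1ccccc1` gives 0.137 h as a measured number. The change to compound 4 `O=C(C1CCN(c2ccccn2)CC1)N1N=CC[C@H]1c1ccccc1` is pyridin-2-yl in place of pyridazin-3-yl on an amine nitrogen in a ring and puts pyridin-2-yl in place of pyridazin-3-yl on an amine nitrogen in a ring. Acetyl stands apart in an at least 22-fold higher number from compound 1 to compound 2 (1.35 log units; beyond the scatter) and in an at least 6.0-fold lower number from compound 2 to compound 3 (0.77 log units; beyond the scatter) while the only step between aromatic groups is a step that the limit leaves unreadable from compound 1 to compound 3 and gives no size. Compound 4 keeps an aromatic ring, so it is expected to lie with compound 1 at 0.137 h and not with compound 2. The expected step is a step that the limit leaves unreadable from compound 3 to compound 4 and it starts from a limit, so its size is rough. The estimated value for compound 4 is 0.22 h with a range from 0.08 h to 0.6 h for now.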

Compound 4, half-life: 0.0633 h
Compound 4: middle estimate off by 3.5-fold (0.54 log units), on the high side, and the stated range ends above it.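

In this assay, two aromatic groups on this amine nitrogen can now be compared through measured numbers: pyridin-2-yl in place of pyrimidin-2-yl gives a 2.2-fold lower number from compound 1 to compound 4 (0.34 log units; beyond the scatter), so the choice of aromatic ring itself moves the half-life. Acetyl also stands far from this second measured aromatic group, with an at least 49-fold lower number from compound 2 to compound 4 (1.69 log units; beyond the scatter), a step that starts from the limit of compound 2. The step from compound 3 cannot be read, as compound 3 carries a limit: the limit of < 0.517 h in this assay, at which 1 of the 4 values shown sits.

Where pyridazin-3-yl lies relative to the other two aromatic groups stays open. Also open, as far as these compounds go, is how a phenyl ring or a longer acyl chain such as propanoyl would stand on this amine nitrogen.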